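Replacing the Diethylaminoethyl Amide with an Acidic Side Chain

A few compounds are considered here, and "the series" means these few. Any claim that something is new, unique, unknown or untested is made for them only; others in the source may bear on it.

Among the measured compounds shown here, compound 1 `CCN(CC)CCNC(=O)c1ccc(C(CC)(CC)c2ccc(OCCC(O)(CC)CC)c(C)c2)n1CC` is the only compound of this pair with a numerical result: in a functional assay on MCF7 cells (Homo sapiens) for antiproliferative activity, read by MTT assay, with a stated time of 48 h (a lower number here means a stronger inhibitor, a higher number a weaker inhibitor), compound 1 gives 550 nM. Compound 2 `CCn1c(C(=O)N(CCC#N)CCC#N)ccc1C(CC)(CC)c1ccc(OCCC(O)(CC)CC)c(C)c1` reached only the limit of this assay, where compound 2 gives > 50000 nM. For the measured compounds named here, the step of an at least 90-fold higher number from compound 1 to compound 2 (1.95 log units; beyond the scatter) is therefore the one measured change at the amide, and it sits at the limit of > 50000 nM in this assay, at which 1 of the 2 values shown sits. Compound 3 `CCC(C)C(NC(=O)c1ccc(C(CC)(CC)c2ccc(OCCC(O)(CC)CC)c(C)c2)n1CC)C(=O)O` differs from compound 1 by 1-carboxy-2-methylbutyl in place of 2-(diethylamino)ethyl on an amide-type nitrogen. Going by the values given here, the only measured step touching the same carbonyl, an at least 90-fold higher number from compound 1 to compound 2 (1.95 log units; beyond the scatter), was a large loss, so a large rise in the number from compound 1 to compound 3 is expected, of roughly a 36-fold higher number from compound 1 to compound 3 (1.56 log units; beyond the scatter), though with a wide band because a second amide change has not been measured. Compound 3 is estimated at 20000 nM, within 3000 nM to 100000 nM, with a fair chance that this assay again reports only a limit.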

Compound 3, half-maximal inhibitory concentration: 11300 nM
Compound 3: middle estimate off by 1.8-fold (0.25 log units), on the high side; low and high end bracket the measured number.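

The change at this amide now has a size that can be read as a number: with 1-carboxy-2-methylbutyl in place of 2-(diethylamino)ethyl on the amide-type nitrogen, this assay shows a 21-fold higher number from compound 1 to compound 3 (1.31 log units; beyond the scatter). Compound 2 gives > 50000 nM, which is a limit of the assay and not a number. Set against that limit, the second step is an at least 4.4-fold lower number from compound 2 to compound 3 (0.64 log units; beyond the scatter), so the two replacements at this carbonyl do not fall equally far.

The compounds shown do not separate the carboxylic acid of 1-carboxy-2-methylbutyl from its branched carbon chain. Going by these compounds, it also remains open how an unbranched chain ending in a carboxylic acid, or a 2-aminoethyl chain carrying a primary amine, would read at this amide nitrogen.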